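The compounds below may be only part of what the source reports. "The series", "measured", "known", "first", "only" and "open" are said of these compounds alone.

In a physicochemical assay for solubility, measured as kinetic solubility, with a stated time of 1 h, at pH 7.4 (on this read-out higher numbers stand for higher solubility and lower numbers for lower solubility), the measured compounds are:

compound 1 `O=C(Nc1nc(-c2ccc(Cl)c(Cl)c2)cs1)c1cccnc1` gives 20000 nM
compound 2 `CC(=O)Nc1nc(-c2cccc(O)c2)cs1` gives 103000 nM
compound 3 `CC(=O)NC1=NN(c2ccc(Cl)c(Cl)c2)CC1` gives 31000 nM

On these numbers compound 3 cannot be told apart from compound 1, since their values lie within the scatter of repeated measurements. Compound 2 has a higher number than compound 3, and that gap lies beyond the scatter.

The next compound, compound 4 `O=C(NC1=NN(c2ccc(Cl)c(Cl)c2)CC1)c1cccnn1`, carries pyridazin-3-yl in place of methyl on a carbonyl carbon. Within the data shown here, no two measured compounds differ in only one place, so no direct step can guide the expectation. The nearest hint is compound 1, which also has a ring on its carbonyl carbon and gives 20000 nM in this assay despite other differences in structure. A small fall is therefore expected, perhaps none beyond the scatter. The estimated change runs a 1.8-fold lower number from compound 3 to compound 4 (0.26 log units; within the scatter) and remains uncertain. For compound 4 the estimated value is 17000 nM with an expected range from 5000 nM to 45000 nM in this measurement.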

Compound 4, solubility: 67000 nM
Estimate against measurement, compound 4: 3.9-fold (0.60 log units) below, outside the stated range (above it).
By their numbers in this assay, from the lowest: compounds 1 and 3 (each within the scatter of the next); then compounds 4 and 2 (each within the scatter of the next).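

Among these compounds, the swap of methyl for pyridazin-3-yl on a carbonyl carbon gives the first direct reading at this position in this assay and amounts to a 2.2-fold higher number from compound 3 to compound 4 (0.33 log units; beyond the scatter), a modest step that lies beyond the scatter. Among the compounds shown here, on this core, then, the position takes a far larger group, with one six-membered aromatic ring, and the number does not fall, which the earlier compounds, differing in more than one place, could not show. Nothing available explains why the number rises.

Still open, on these data alone, is whether the rise depends on the ring nitrogens or would come with any ring, which a phenyl or pyridin-3-yl on the same carbonyl carbon would help to separate. One step also leaves open how a non-aromatic group such as morpholine or a longer alkyl chain would behave here.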